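Pyridin-3-yl in Place of Methoxyphenyl on the Amide Carbonyl

A few compounds are considered here, and "the series" means these few. Any claim that something is new, unique, unknown or untested is made for them only; others in the source may bear on it.

Compound 1 `Cc1cccc(S(=O)(=O)NCc2ccc(CNC(=O)c3cccnc3)cc2)c1`: 10 nM
Compound 2 `COc1ccccc1C(=O)NCc1ccc(CNS(=O)(=O)c2cccc3ccccc23)cc1`: > 1000 nM
Compound 3 `COc1ccccc1C(=O)NCc1ccc(CNS(=O)(=O)c2cccc(Cl)c2)cc1`: 1000 nM

In an assay on MDA-MB-231 cells for displacement of a labelled ligand from C-X-C chemokine receptor type 4 (Homo sapiens), read by fluorescence and microscopy, with stated times of 10 min and 30 min (on this read-out higher numbers stand for an effect only at larger amounts of compound and lower numbers for an effect already at smaller amounts), compound 1 gives 10 nM. Compound 2 reaches only the limit of this assay, > 1000 nM. Compound 3 gives 1000 nM, the highest of the two numbers shown, and compound 1 stands a long way lower, beyond the scatter. For the measured compounds named here, the only measured step, a number no higher from compound 2 to compound 3 (the limit leaves the size open), concerns 3-chlorophenyl in place of naphthalen-1-yl on a sulfonyl sulfur, and its size cannot be read because the limit of > 1000 nM in this assay, at which 1 of the 3 values shown sits, caps one end of it.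

Compound 4 `O=C(NCc1ccc(CNS(=O)(=O)c2cccc(Cl)c2)cc1)c1cccnc1` differs from compound 3 by pyridin-3-yl in place of 2-methoxyphenyl on a carbonyl carbon. Going by the values given here, no measured step covers this change: the one step shown sits on the sulfonyl side and does not bear on the carbonyl side. Compound 1 carries the same pyridin-3-yl on its carbonyl carbon, but it also differs from compound 3 on the sulfonyl side, so the two values only show that both changes together go with a far lower number. Compound 4 is therefore expected to sit between the two, at an estimated 100 nM with a range from 10 nM to 1000 nM. The expected step of a 10-fold lower number from compound 3 to compound 4 (1.00 log units; beyond the scatter) is toward a lower number, though its size is uncertain.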

Compound 4, effective concentration (reported as EC, without a stated level of effect): 100 nM
Compound 4: the middle estimate sits on the measured number at the digits printed; measured number inside the range.
By their numbers in this assay, from the lowest: compound 1; then compound 4; then compound 3.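

In this assay the carbonyl side now has a step of its own, with the sulfonyl side held fixed: a 10-fold lower number from compound 3 to compound 4 (1.00 log units; beyond the scatter) for pyridin-3-yl in place of 2-methoxyphenyl on a carbonyl carbon. The wide gap in numbers between compound 1 and compound 3 therefore comes apart into two readable parts, the second being a 10-fold higher number from compound 1 to compound 4 (1.00 log units; beyond the scatter) for chloro in place of methyl on an aromatic carbon, with pyridin-3-yl kept on the carbonyl carbon. Both changes thus go with a step beyond the scatter, and each can now be seen alone, although nothing at hand gives a reason for either step.

On these data alone, whether the step to pyridin-3-yl would be of the same size with another group on the sulfonyl sulfur, such as the naphthalen-1-yl of compound 2, remains open. Also open, as far as these compounds go, is what other groups on this carbonyl carbon would give, for example pyridin-4-yl, or a phenyl ring carrying a carboxylic acid or an amine.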